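The compounds below may be only part of what the source reports. "The series", "measured", "known", "first", "only" and "open" are said of these compounds alone.

Compound 3 `CN(C)CCC(NC(=O)NCc1ccccc1)c1ccc(Cl)cc1` stands second highest of the three numbers in an assay on NIH3T3 cells with Urotensin-2 receptor (Homo sapiens) as the target (a lower number here means a smaller maximal response, a higher number a larger maximal response), where compound 3 gives 179%. Compound 1 `Cc1ccccc1NC(=O)NC(CCN(C)C)c1ccc(Cl)cc1` gives 175%, and compound 2 `COc1ccc(NC(=O)NC(CCN(C)C)c2ccc(Cl)cc2)cc1` gives 195%. The step of a number 4 percentage points higher from compound 1 to compound 3 (within the scatter) lies within the scatter, whereas the step of a number 16 percentage points lower from compound 2 to compound 3 (beyond the scatter) lies beyond it. Compound 4 `COc1cccc(NC(=O)NC(CCN(C)C)c2ccc(Cl)cc2)c1` is not yet measured; its change from compound 3 is 3-methoxyphenyl in place of benzyl on an amide-type nitrogen. Going by the values given here, only the step from compound 2 to compound 3 bears on this change, as it removed a methoxyphenyl in favour of benzyl and was modest, and that step is here reversed with the methoxy group on a different carbon. An increase of modest size is therefore expected, as a number 11 percentage points higher from compound 3 to compound 4 (beyond the scatter). Compound 4 is estimated at 190%, with a range from 170% to 210%.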

Compound 4, largest response reached (reported as efficacy), in percent of the reference or control that the assay uses: 146%
Compound 4: the middle estimate sits 44 percentage points above what was measured; the whole stated range lies above it.
By their numbers in this assay, from the lowest: compound 4; then compounds 1 and 3 (each within the scatter of the next); then compound 2.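

In this assay, the place of the methoxy group on the phenyl ring at the amide-type nitrogen matters, with a number 49 percentage points lower from compound 2 to compound 4 (beyond the scatter) when 3-methoxyphenyl replaces 4-methoxyphenyl. The 3-methoxyphenyl group also falls short of the other two groups, with a number 33 percentage points lower from compound 3 to compound 4 (beyond the scatter) against benzyl and a number 29 percentage points lower from compound 1 to compound 4 (beyond the scatter) against 2-methylphenyl, so a methoxyphenyl group here does not by itself give a high response. Nothing available explains this difference. The compounds leave open whether the lower response follows the methoxy group or its ring position, which a 3-methylphenyl or 3-chlorophenyl group could separate. From the compounds shown here alone, how a 2-methoxyphenyl group compares also remains open.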